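From 4-methylphenyl to 2-methoxyphenyl at the assay limit

The source may hold more compounds than are shown below. What is called first, only, known or untested is meant among the compounds shown, and "the series" means these compounds.

Compound 1 `COc1cc(-n2ncnc2-c2ccc(C)cc2)cc(OC)c1OC`: > 10000 nM (a limit)
Compound 2 `COc1cc(-c2ncnn2-c2cccc(N)c2)cc(OC)c1OC`: > 10000 nM (a limit)
Compound 3 `CCOc1cccc(-c2ncnn2-c2cc(OC)c(OC)c(OC)c2)c1`: > 10000 nM (a limit)

All three entries come from a functional assay on K562 cells (Homo sapiens) for antiproliferative activity, read by MTT assay, with a stated time of 72 h; a higher number here means a weaker inhibitor, a lower number a stronger inhibitor. Compound 1 gives no number there, and its > 10000 nM is a limit. Within the data shown here, the series so far shows (the limit of > 10000 nM in this assay, at which 3 of the 3 values shown sit). Compound 4 `COc1ccccc1-c1ncnn1-c1cc(OC)c(OC)c(OC)c1` keeps the core of compound 1 and carries 2-methoxyphenyl in place of 4-methylphenyl on an aromatic carbon. Among the measured compounds shown here, no measured step between compounds that differ in one place is available, so no step beyond the scatter is expected in either direction, on the strength of the limit of > 10000 nM in this assay, at which 3 of the 3 values shown sit. The expected change is a step that the limit leaves unreadable from compound 1 to compound 4. For compound 4 the estimate is 12000 nM, with an expected range from 3000 nM to 40000 nM.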

Compound 4, half-maximal inhibitory concentration: > 10000 nM
Compound 4: a limit, no number (the forecaster's own chance of this, stated with the estimate: 75%); the middle value does not contradict the limit.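

In this assay, among these compounds, compound 1 and compound 4 both stand at a limit and give no number, so no step between them can be read. The compounds shown leave open how 2-methoxyphenyl and 4-methylphenyl compare, and which change to the shared core would give a measurable value.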